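Urea Tail Variation on a Triarylethylene Core

This account rests on a few compounds, and the source may have more. Where it says the series, first, only, none or still open, it means among the compounds named here.

Measured so far:
compound 1, `COc1ccc(/C(=C(/CCCl)c2ccccc2)c2ccccc2)cc1`: > 50000 nM
compound 2, `COc1ccc(/C(=C(/CCNC(=O)NCc2ccccc2)c2ccccc2)c2ccccc2)cc1`: > 50000 nM

In a functional assay on MDA-MB-231 cells (Homo sapiens) for cytotoxicity, read by MTT assay, with a stated time of 72 h (on this read-out lower numbers stand for stronger inhibition and higher numbers for weaker inhibition), compound 1 gives > 50000 nM, which is a limit of the assay rather than a number. Compound 2 likewise gives > 50000 nM, again a limit. Both sit at the limit of > 50000 nM in this assay, at which 2 of the 2 values shown sit, so the step that the two limits leave unreadable from compound 1 to compound 2 cannot be sized. Compound 2 therefore stands at the limit, with no readable number beside it.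

Compound 3, `COc1ccc(/C(=C(/CCNC(=O)N2CCOCC2)c2ccccc2)c2ccccc2)cc1`, differs from compound 2 by morpholin-4-yl in place of benzylamino on a carbonyl carbon. Within the data shown here, no measured step touches this part of the molecule, and the one measured step is unreadable, so nothing in the data points to a direction. Compound 3 is expected to give about 50000 nM, within a range of 20000 nM to 100000 nM, which is expected to amount to a number no higher from compound 2 to compound 3 (the limit leaves the size open), most likely again only a limit.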

Compound 3, half-maximal inhibitory concentration: 42800 nM
Beside the measured number, compound 3's estimate is 1.2-fold (0.07 log units) above it; the range from low to high includes it.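

In this assay compound 3 has the only readable number among the compounds shown, so the urea tail now has a measured value and not just a limit: the limit of > 50000 nM in this assay, at which 2 of the 3 values shown sit. Morpholin-4-yl in place of benzylamino on a carbonyl carbon gives an at least 1.1-fold lower number from compound 2 to compound 3 (0.06 log units; that floor lies within the scatter), and ((morpholin-4-yl)carbonyl)amino in place of chloro gives an at least 1.1-fold lower number from compound 1 to compound 3 (0.06 log units; that floor lies within the scatter). Both steps are known only as floors, so they show no change beyond the scatter, though the true size of either may be larger.

Going by these compounds, the real size of these two steps remains open, as compound 1 and compound 2 give limits and not numbers. Also open, on these data alone, is whether piperazin-1-yl or dimethylamino on the carbonyl carbon, or a longer chain carrying the urea, would give a lower number.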